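A 2-Chlorophenyl Group Gives Way to 4-Chlorophenyl

This account rests on a few compounds, and the source may have more. Where it says the series, first, only, none or still open, it means among the compounds named here.

In a functional assay on MCF7 cells (Homo sapiens) for antiproliferative activity, read by MTT assay, with a stated time of 72 h (a higher number here means a weaker inhibitor, a lower number a stronger inhibitor), compound 1 (`O=C(Nc1ccc(Nc2nccc(NC3CC3)n2)cc1)Nc1ccc(Cl)c(C(F)(F)F)c1`) gives 38300 nM, compound 2 (`CCCNc1ccnc(Nc2ccc(NC(=O)Nc3ccc(Cl)c(C(F)(F)F)c3)cc2)n1`) gives 4610 nM, and compound 3 (`O=C(Nc1ccc(Nc2nccc(Nc3ccccc3Cl)n2)cc1)Nc1ccc(Cl)c(C(F)(F)F)c1`) gives 27900 nM. Compound 3 is not separated from compound 1 by more than the scatter, while compound 2 is the strongest of the three. The two steps that place compound 3 are a 1.4-fold lower number from compound 1 to compound 3 (0.14 log units; within the scatter) and a 6.1-fold higher number from compound 2 to compound 3 (0.78 log units; beyond the scatter). Compound 4 (`O=C(Nc1ccc(Nc2nccc(Nc3ccc(Cl)cc3)n2)cc1)Nc1ccc(Cl)c(C(F)(F)F)c1`) differs from compound 3 in one place: 4-chlorophenyl in place of 2-chlorophenyl on a nitrogen on an aromatic ring. Among the measured compounds shown here, no measured step moves a chlorine around a ring, so the evidence is indirect. Changes on this nitrogen can matter, as seen in an 8.3-fold lower number from compound 1 to compound 2 (0.92 log units; beyond the scatter), where propyl replaces cyclopropyl. However, replacing cyclopropyl with 2-chlorophenyl produced no change beyond the scatter. Swapping one chlorophenyl group for another is therefore expected to produce little change, with no firm direction. The expected step is a 1.2-fold lower number from compound 3 to compound 4 (0.07 log units; within the scatter). Compound 4 is estimated at 24000 nM, with an expected range of 8000 nM to 60000 nM.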

Compound 4, half-maximal inhibitory concentration: 12800 nM
Beside the measured number, compound 4's estimate is 1.9-fold (0.27 log units) above it; low and high end bracket the measured number.
By their numbers in this assay, from the lowest: compound 2; then compound 4; then compounds 3 and 1 (each within the scatter of the next).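

In this assay the same atoms joined differently give a 2.2-fold lower number from compound 3 to compound 4 (0.34 log units; beyond the scatter) and so show that this nitrogen responds to where the chlorine sits on the phenyl ring, not only to which kind of group it carries. The 4-chlorophenyl group also gives a 3.0-fold lower number from compound 1 to compound 4 (0.48 log units; beyond the scatter) and thereby separates from cyclopropyl by more than the scatter, which the 2-chlorophenyl group did not do. Even so, a 2.8-fold higher number from compound 2 to compound 4 (0.44 log units; beyond the scatter) leaves the propyl chain with the lowest number of the four, so neither chlorophenyl group matches it here. On these data alone, whether 3-chlorophenyl, unsubstituted phenyl or a butyl chain on this nitrogen would lower the number further remains open. Nothing measured here accounts for the difference between the two chlorophenyl groups.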